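Three Limits at the Ring Nitrogen and an Ester Variant

A few compounds are considered here, and "the series" means these few. Any claim that something is new, unique, unknown or untested is made for them only; others in the source may bear on it.

Compound 1, `CN1C(=O)C2(C(C#N)=C(N)Oc3cc4oc(-c5ccccc5)cc(=O)c4c(O)c32)c2ccccc21`, gives in a functional assay on A549 cells (Homo sapiens) for antiproliferative activity, read by MTT assay, with a stated time of 48 h (on this read-out higher numbers stand for weaker inhibition and lower numbers for stronger inhibition), only the limit > 50000 nM.
Compound 2, `CN1C(=O)C2(C(C#N)=C(N)Oc3cc4oc(-c5ccccc5)cc(=O)c4c(O)c32)c2cccc(Cl)c21`, gives in this assay only the limit > 50000 nM.
Compound 3, `N#CC1=C(N)Oc2cc3oc(-c4ccccc4)cc(=O)c3c(O)c2C12C(=O)N(c1ccccc1)c1ccccc12`, gives in this assay only the limit > 50000 nM.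

Compound 3 therefore stands where the other two stand, at the common limit described by the limit of > 50000 nM in this assay, at which 3 of the 3 values shown sit, and no number sets it apart from compound 1 or compound 2. Both measured steps, a step that the two limits leave unreadable from compound 1 to compound 2 and a step that the two limits leave unreadable from compound 1 to compound 3, are hidden by these limits, so neither the chloro substituent on the aromatic carbon nor the exchange of methyl for phenyl at the ring nitrogen has a readable size in this assay.

Compound 4, `CC(C)(C)OC(=O)CN1C(=O)C2(C(C#N)=C(N)Oc3cc4oc(-c5ccccc5)cc(=O)c4c(O)c32)c2ccccc21`, differs from compound 3 by (tert-butoxycarbonyl)methyl in place of phenyl on an amide-type nitrogen in a ring. Within the data shown here, the only measured step at the same place is a step that the two limits leave unreadable from compound 1 to compound 3, and it shows no size; the chloro step shows none either. Nothing among the three compounds points to inhibition that would rise above the limit once the phenyl is replaced by the ester-bearing chain.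

Compound 4 is therefore expected to remain at or near the limit, with an estimate of 60000 nM and a range from 20000 nM to 200000 nM. The step this implies, a step that the limit leaves unreadable from compound 3 to compound 4, is expected to be within the scatter, with a strong chance that only a limit is reported.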

Compound 4, half-maximal inhibitory concentration: > 50000 nM
Compound 4 was reported as a limit; the forecaster's own chance of this, stated with the estimate: 80%; the middle value is on the limit's open side.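

In this assay compound 4 gives only a limit, > 50000 nM. No size can be read for the steps to compound 4 from compound 3 or from compound 1, and all the compounds shown share one limit: the limit of > 50000 nM in this assay, at which 4 of the 4 values shown sit. The compounds shown leave open whether any group on the ring nitrogen, or the chloro substituent, changes inhibition at all.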